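Lengthening the Urea Chain: From Ethyl to Propyl

The source may report more compounds than this note shows. Statements on the series, on what has been measured and on what is new or still open speak of the compounds shown alone.

Compound 2 `CCNC(=O)Nc1c(OCCCn2cnc(-c3ccccc3)c2)cccc1N(C)C` carries an ethylamino urea on the shared core. Among the compounds with values here, in an assay for inhibition of acyl-CoA:cholesterol acyltransferase (Oryctolagus cuniculus), using microsomes (on this read-out lower numbers stand for stronger inhibition and higher numbers for weaker inhibition), compound 2 gives 870 nM, the highest of the two numbers measured so far; its nearest neighbour is compound 1 `CCCCNC(=O)Nc1c(OCCCn2cnc(-c3ccccc3)c2)cccc1N(C)C`, which in this assay gives 140 nM. Within the data shown here, the single measured step, a 6.2-fold higher number from compound 1 to compound 2 (0.79 log units; beyond the scatter), is the only one that bears on the new compound, since it alters the same chain at the same place. Compound 3 `CCCNC(=O)Nc1c(OCCCn2cnc(-c3ccccc3)c2)cccc1N(C)C` differs from compound 2 by methyl in place of hydrogen on a saturated chain carbon, two bonds along the chain from an amide-type nitrogen, so that ethylamino becomes propylamino. Because the measured step of a 6.2-fold higher number from compound 1 to compound 2 (0.79 log units; beyond the scatter) came from shortening that chain, adding one carbon back is expected to move the number part of the way back toward compound 1. Compound 3 is therefore estimated at 350 nM in this assay, within 150 nM to 800 nM, a step of a 2.5-fold lower number from compound 2 to compound 3 (0.40 log units; beyond the scatter).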

Compound 3, half-maximal inhibitory concentration: 660 nM
Estimate against measurement, compound 3: 1.9-fold (0.28 log units) below; low and high end bracket the measured number.
By their numbers in this assay, from the lowest: compound 1; then compounds 3 and 2 (each within the scatter of the next).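

In this assay, methyl in place of hydrogen, which turns ethylamino into propylamino, gives a 1.3-fold lower number from compound 2 to compound 3 (0.12 log units; within the scatter) and so cannot be told apart from the usual variation between repeats. The step at the next carbon along is different: hydrogen in place of methyl on a saturated chain carbon, three bonds along the chain from an amide-type nitrogen, gives a 4.7-fold higher number from compound 1 to compound 3 (0.67 log units; beyond the scatter) and thus places the measurable gap within this series of three at that outer carbon, not the inner one. Nothing available accounts for this difference between the two carbons.

The compounds shown leave open whether a chain longer than that of compound 1 would lower the number further or raise it again. They also leave open how a branched chain, a cyclohexyl group or a terminal hydroxyl would read at this position.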